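Compound 3 to compound 4: a series at its limit

The source may report more compounds than this note shows. Statements on the series, on what has been measured and on what is new or still open speak of the compounds shown alone.

- compound 1 `CCOC(=O)CCCCCOc1cccc(CN(C(=O)c2ccc(-c3cccc(NC(C)=O)c3)cc2)C(C)C)c1` gives > 26000 nM (a limit)
- compound 2 `CCOC(=O)CCCCCOc1cccc(CN(C(=O)c2ccc(-c3cnc(OC)nc3OC)cc2)C(C)C)c1` gives > 26000 nM (a limit)
- compound 3 `CCOC(=O)CCCCCOc1cccc(CN(C(=O)c2ccc(-c3cc(OC)cc(OC)c3)cc2)C(C)C)c1` gives > 26000 nM (a limit)

All readings come from an ADME assay on HepG2 cells (Homo sapiens) for cytotoxicity, read by CellTiter-Glo and resazurin assay, with a stated time of 72 h (on this read-out higher numbers stand for an effect only at larger amounts of compound and lower numbers for an effect already at smaller amounts), and none is a number. The set as a whole shows the limit of > 26000 nM in this assay, at which 3 of the 3 values shown sit, and nothing finer. The next structure is compound 4 `CCOC(=O)CCCCCOc1cccc(CN(C(=O)c2ccc(-c3cc(OC)ccc3F)cc2)C(C)C)c1`, and the change is 2-fluoro-5-methoxyphenyl in place of 3,5-dimethoxyphenyl on an aromatic carbon with 2-fluoro-5-methoxyphenyl in place of 3,5-dimethoxyphenyl.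

Three swaps at this same place bear on it: a step that the two limits leave unreadable from compound 1 to compound 2, a step that the two limits leave unreadable from compound 1 to compound 3 and a step that the two limits leave unreadable from compound 2 to compound 3. None has a readable size, so no direction can be drawn from them. The expected outcome is a number no higher from compound 3 to compound 4 (the limit leaves the size open) and nothing beyond the scatter is foreseen. A further limit is the likeliest report. The estimate for compound 4 is 26000 nM within 13000 nM to 52000 nM as the expected range.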

Compound 4, half-maximal effective concentration: > 26000 nM
Compound 4: no number, only a limit (the forecaster's own chance of this, stated with the estimate: 80%); the middle value lies on the limit itself.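

No step from compound 1, compound 2 or compound 3 to compound 4 can be read, since every value is only a limit: the limit of > 26000 nM in this assay, at which 4 of the 4 values shown sit.

The compounds shown leave open whether any group at this place gives a measurable effect, and how far these four compounds truly differ.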